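Adding a methoxy group to the core of compound 1

The compounds below may be only part of what the source reports. "The series", "measured", "known", "first", "only" and "open" are said of these compounds alone.

Compound 1 `C[C@H](Oc1ccc(S(C)(=O)=O)cc1C(=O)N1Cc2ccccc2C1)C(F)(F)F`: in an assay on CHO cells for inhibition of sodium- and chloride-dependent glycine transporter 1 (Homo sapiens), read by scintillation counting (a lower number here means that less compound is needed, a higher number that more compound is needed for the effect), compound 1 gives 2540 nM
Compound 2 `C[C@H](Oc1ccc(S(C)(=O)=O)cc1C(=O)N1Cc2ccc(N3CCCC3)cc2C1)C(F)(F)F`: in this assay compound 2 gives 180 nM

Among the compounds with values here, compound 1 has the higher of the two numbers, so more of it is needed than of compound 2; the one step away from it runs a 14-fold lower number from compound 1 to compound 2 (1.15 log units; beyond the scatter). Compound 3 `COc1cccc2c1CN(C(=O)c1cc(S(C)(=O)=O)ccc1O[C@@H](C)C(F)(F)F)C2` differs from compound 1 by methoxy in place of hydrogen on an aromatic carbon. Within the data shown here, only that single step bears on this change, and it was large, but it placed a different group, a ring, at another aromatic carbon of the same fused system. On these data alone, a methoxy group at the carbon ortho to the fused ring is untested here. A smaller gain, if any, is expected, giving a 1.7-fold lower number from compound 1 to compound 3 (0.23 log units; within the scatter). Compound 3 is therefore estimated at 1500 nM, in the range 500 nM to 4500 nM.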

Compound 3, half-maximal effective concentration: 1940 nM
Beside the measured number, compound 3's estimate is 1.3-fold (0.11 log units) below it; low and high end bracket the measured number.
By their numbers in this assay, from the lowest: compound 2; then compounds 3 and 1 (each within the scatter of the next).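

At this aromatic carbon, ortho to a fused ring, methoxy in place of hydrogen gives a 1.3-fold lower number from compound 1 to compound 3 (0.12 log units; within the scatter) in this assay, so the change cannot be told apart from the spread of repeated measurements. Within the data shown here, the large step seen earlier, a 14-fold lower number from compound 1 to compound 2 (1.15 log units; beyond the scatter), therefore has no visible counterpart with this group at this carbon, although the two changes differ in both the group and its place, so these compounds cannot separate those two factors. Nothing shown here gives a measured reason for this result.

On these data alone, it remains open whether a dimethylamino group or a longer chain such as ethoxy at this same carbon would give a step beyond the scatter. Also open, as far as these compounds go, is how methoxy would behave on the carbon that carries the pyrrolidin-1-yl ring in compound 2.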